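Methyl in Place of Methoxy in Two Related Series

The source may report more compounds than this note shows. Statements on the series, on what has been measured and on what is new or still open speak of the compounds shown alone.

Measured compounds:
Compound 1 `COc1cccc(-c2nc3c(=O)[nH]c(C)nc3s2)c1`: 1%
Compound 2 `Cc1cccc(-c2nc3c(=O)[nH]c(C)nc3s2)c1`: 1%
Compound 3 `COc1ccc(Nc2nc3c(=O)[nH]c(C)nc3s2)cc1`: 1%

In an assay on CHO cells for displacement of a labelled ligand from adenosine receptor A1 (Homo sapiens), read by scintillation counting, with a stated time of 120 min, tested at 1 uM (on this read-out lower numbers stand for less inhibition and higher numbers for more inhibition at the one concentration tested (going by the name of the read-out)), compound 1 gives 1%. Compound 2 carries a methyl where compound 1 carries a methoxy. In this assay compound 2 gives 1%. The change between them is methyl in place of methoxy on an aromatic carbon, and the step it made is no change at the digits printed from compound 1 to compound 2 (within the scatter). Compound 3 gives 1% in this assay, level with compound 1 and compound 2 within the scatter; the difference between the cores of compound 1 and compound 3 is not broken down here.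

Compound 4 `Cc1ccc(Nc2nc3c(=O)[nH]c(C)nc3s2)cc1` has not yet been measured. It stands to compound 3 as compound 2 stands to compound 1: the change is methyl in place of methoxy on an aromatic carbon. The two changes are the same kind of change rather than the same one, since in compound 1 the methoxy sits meta to a large group, whereas in compound 3 it sits para to a large group.

Because the step of no change at the digits printed from compound 1 to compound 2 (within the scatter) showed no change, and because compound 3 sits at 1%, the same kind of change on compound 3 is expected to give a number 1 percentage points higher from compound 3 to compound 4 (within the scatter). Compound 4 is therefore expected to give about 2% in this assay, estimated between 0% and 12%. This rests on three compounds only, and a different outcome cannot be ruled out.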

Compound 4, a percentage reported as inhibition, at one concentration (the size of the read-out at that concentration, not a potency): 20%
Beside the measured number, compound 4's estimate is 18 percentage points below it; measured number above the stated range.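

On the core of compound 3, putting methyl in place of methoxy gives, in this assay, a number 19 percentage points higher from compound 3 to compound 4 (beyond the scatter). Set beside the earlier step, the same kind of change did not behave alike on the two cores: the same change on two cores in this assay, no change at the digits printed (within the scatter) from compound 1 to compound 2 and a number 19 percentage points higher (beyond the scatter) from compound 3 to compound 4, 19 percentage points apart, beyond the scatter of two such steps. So the outcome on the core of compound 1 did not carry over to the core of compound 3, but this rests on just two pairs and does not show why they part: the cores differ, the change may not sit in the same place on each, and compound 4, at 20%, was read at a single concentration, which gives the size of the inhibition there and not a potency.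

The compounds shown leave open whether the higher number on the core of compound 3 is specific to methyl or would also appear with another group in that place, para to a large group, such as an ethyl chain, a chlorine atom or an amine. They also leave open how the two cores would compare with methoxy and methyl placed alike on each, and whether the gap would hold at other concentrations.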